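The compounds below may be only part of what the source reports. "The series", "measured", "known", "first", "only" and "open" are said of these compounds alone.

In an ADME assay on MT4 cells (Homo sapiens) for cytotoxicity (a lower number here means that less compound is tolerated, a higher number that more compound is tolerated), three compounds share one core and differ only in a group on an aromatic carbon: compound 1 `COC(=O)N[C@H](C(=O)NN(CCC[C@@](O)(Cc1ccccc1)C(=O)N[C@H]1c2ccccc2C[C@H]1O)Cc1ccc(C#N)cc1)C(C)(C)C`, compound 2 `COC(=O)N[C@H](C(=O)NN(CCC[C@@](O)(Cc1ccccc1)C(=O)N[C@H]1c2ccccc2C[C@H]1O)Cc1ccc(N(C)C)cc1)C(C)(C)C` and compound 3 `COC(=O)N[C@H](C(=O)NN(CCC[C@@](O)(Cc1ccccc1)C(=O)N[C@H]1c2ccccc2C[C@H]1O)Cc1ccc(-c2cncnc2)cc1)C(C)(C)C`. Compound 1 gives > 10000 nM, which is a limit and not a number. Compound 2 gives > 10000 nM, again a limit. Compound 3 gives > 10000 nM, also a limit. So compound 3 stands with the others, as the limit of > 10000 nM in this assay, at which 3 of the 3 values shown sit.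

The next compound is compound 4 `COC(=O)N[C@H](C(=O)NN(CCC[C@@](O)(Cc1ccccc1)C(=O)N[C@H]1c2ccccc2C[C@H]1O)Cc1ccc(-c2csc(C)n2)cc1)C(C)(C)C`, which carries 2-methyl-1,3-thiazol-4-yl in place of pyrimidin-5-yl on an aromatic carbon.

Three measured swaps of a group at this kind of place bear on the change: a step that the two limits leave unreadable from compound 1 to compound 2, a step that the two limits leave unreadable from compound 1 to compound 3 and a step that the two limits leave unreadable from compound 2 to compound 3. None of them offers a size to carry over, and none points in a direction. No shift beyond the usual scatter is therefore expected, and the estimate is a step that the limit leaves unreadable from compound 3 to compound 4. For compound 4 the expected value is 15000 nM, with an estimated range from 6000 nM to 50000 nM.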

Compound 4, half-maximal cytotoxic concentration: > 10000 nM
Compound 4 was reported as a limit; the forecaster's own chance of this, stated with the estimate: 85%; the middle value is on the limit's open side.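

In this assay compound 4 gives > 10000 nM, again a limit and not a number, so the steps to it from compound 1, compound 2 and compound 3 cannot be read. The compounds shown leave open whether changing the group on the aromatic carbon shifts the tolerated concentration at all, because every value sits in one place: the limit of > 10000 nM in this assay, at which 4 of the 4 values shown sit.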